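From 4-fluorophenyl to 3-bromophenyl at an assay limit

The source may hold more compounds than are shown below. What is called first, only, known or untested is meant among the compounds shown, and "the series" means these compounds.

In an ADME assay on SH-SY5Y cells (Homo sapiens) for cytotoxicity, read by MTT assay, with a stated time of 72 h (on this read-out lower numbers stand for stronger inhibition and higher numbers for weaker inhibition), compound 3 `COc1ccc2[nH]cc(CCCN3CCN(C(=O)CN4CCN(C(=O)c5ccc(F)cc5)CC4)CC3)c2c1` stands at > 200000 nM as a limit and not a number. Compound 1 `COc1ccc2[nH]cc(CCCN3CCN(C(=O)CN4CCN(C(=O)c5ccccc5)CC4)CC3)c2c1` reads > 200000 nM and this too is a limit. Compound 2 `COc1ccc2[nH]cc(CCCN3CCN(C(=O)CN4CCN(C(=O)c5ccc(Cl)cc5)CC4)CC3)c2c1` gives 159000 nM as an actual number. The set thus meets the limit of > 200000 nM in this assay, at which 2 of the 3 values shown sit, and compound 3 offers no exact starting point.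

Compound 4 `COc1ccc2[nH]cc(CCCN3CCN(C(=O)CN4CCN(C(=O)c5cccc(Br)c5)CC4)CC3)c2c1` differs from compound 3 by 3-bromophenyl in place of 4-fluorophenyl on a carbonyl carbon and the change is 3-bromophenyl in place of 4-fluorophenyl on a carbonyl carbon. Adding chloro gives an at least 1.2-fold lower number from compound 1 to compound 2 (0.09 log units; that floor lies within the scatter) in the measured set. Exchanging chloro for fluoro gives an at least 1.2-fold higher number from compound 2 to compound 3 (0.09 log units; that floor lies within the scatter) in turn. Adding fluoro gives a step that the two limits leave unreadable from compound 1 to compound 3 as the third step. None of these is read beyond the scatter, and no bromo group has been measured.

Within the data shown here, the expectation rests on compound 2 at 159000 nM as the only number available. The expected change is an at least 1.3-fold lower number from compound 3 to compound 4 (0.12 log units; that floor lies within the scatter) toward lower numbers and no larger than the scatter. For compound 4 the estimate is 150000 nM with an expected range from 70000 nM to 300000 nM in this assay and a limit of the assay stays possible.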

Compound 4, half-maximal inhibitory concentration: 105000 nM
Compound 4: the middle estimate sits 1.4-fold (0.15 log units) above what was measured; the measured number falls inside the stated range.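

In this assay, among these compounds, compound 4 gives the series its second actual number and so the first step between two actual numbers: a 1.5-fold lower number from compound 2 to compound 4 (0.18 log units; within the scatter), which does not tell 3-bromophenyl from 4-chlorophenyl on this carbonyl carbon. Against the two limits the change yields only floors, an at least 1.9-fold lower number from compound 3 to compound 4 (0.27 log units; that floor lies within the scatter) and an at least 1.9-fold lower number from compound 1 to compound 4 (0.27 log units; that floor lies within the scatter), and neither floor goes beyond the scatter. Compound 1 and compound 3 remain limits and not numbers: the limit of > 200000 nM in this assay, at which 2 of the 4 values shown sit.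

As far as these compounds go, whether any difference between 3-bromophenyl and 4-chlorophenyl would belong to the halogen or to its place on the ring stays open, for the two change together in this step. Also open, from the compounds shown here alone, is how an amine or a carboxylic acid in place of the halogen would read in this assay.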